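This account rests on a few compounds, and the source may have more. Where it says the series, first, only, none or still open, it means among the compounds named here.

Working notes on the series. For the measured compounds named here, in a functional assay on A549 cells (Homo sapiens) for inhibition, read by MTT assay, with a stated time of 24 h (a higher number here means a weaker inhibitor, a lower number a stronger inhibitor), compound 1 `CC1(C)[C@H]2CC[C@]1(C)N(Cc1cn(-c3cccc(Cl)c3)nn1)C(=O)C2` gives 60 nM and compound 2 `Cc1ccc(-n2cc(CN3C(=O)C[C@@H]4CC[C@@]3(C)C4(C)C)nn2)cc1` gives 400 nM, so compound 2 holds the higher of the two numbers so far. Compound 3 `CC1(C)[C@H]2CC[C@]1(C)N(Cc1cn(-c3cccc(O)c3)nn1)C(=O)C2` carries 3-hydroxyphenyl in place of 4-methylphenyl on an aromatic nitrogen of the five-membered aromatic ring with 3 nitrogen: 3-hydroxyphenyl in place of 4-methylphenyl on an aromatic nitrogen. Going by the values given here, one measured step bears on this place: a 6.7-fold higher number from compound 1 to compound 2 (0.82 log units; beyond the scatter), a modest change beyond the scatter, with 4-methylphenyl in place of 3-chlorophenyl. Among the compounds with values here, no 3-hydroxyphenyl compound has a number yet, so that step guides direction only loosely. By name, the entering group lies closer to the 3-chlorophenyl of compound 1, at 60 nM, than to the group it replaces. A smaller move toward a lower number is therefore expected in this assay. The expected move is a 2.2-fold lower number from compound 2 to compound 3 (0.35 log units; beyond the scatter). For compound 3 the estimated value is 180 nM, with an expected range of 45 nM to 750 nM.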

Compound 3, half-maximal inhibitory concentration: 180 nM
Beside the measured number, compound 3's estimate shows no gap at the digits printed; measured number inside the range.
By their numbers in this assay, from the lowest: compound 1; then compound 3; then compound 2.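

In this assay, the hydroxy compound gives a 2.2-fold lower number from compound 2 to compound 3 (0.35 log units; beyond the scatter), so a 3-substituted phenyl group with 1 hydrogen-bond donor and 1 hydrogen-bond acceptor stands lower than the 4-methylphenyl group, which has neither, though this step changes both the group and where it sits on the phenyl ring. The cleaner comparison keeps the substituent's place fixed and shows a 3.0-fold higher number from compound 1 to compound 3 (0.48 log units; beyond the scatter), so hydroxy in place of chloro on an aromatic carbon still moves the number beyond the scatter, and the 3-chlorophenyl group remains the lowest of the three. No measurement at hand accounts for either step.

A 3-methylphenyl or 4-chlorophenyl group would separate the effect of the substituent from that of its place on the phenyl ring. On these data alone, how a 3-aminophenyl or 3-methoxyphenyl group compares with the 3-hydroxyphenyl group remains open.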